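A second trifluoromethyl on the urea aryl ring

A few compounds are considered here, and "the series" means these few. Any claim that something is new, unique, unknown or untested is made for them only; others in the source may bear on it.

Compound 1 `O=C(Nc1cccc(-n2cc(-c3ccncc3)c(-c3ccc(Cl)c(O)c3)n2)c1)Nc1cc(C(F)(F)F)cc(C(F)(F)F)c1`, 4390 nM
Compound 2 `COc1cc(-c2nn(-c3cccc(NC(=O)Nc4cccc(C(F)(F)F)c4)c3)cc2-c2ccncc2)ccc1Cl`, 3200 nM
Compound 3 `COc1cc(-c2nn(-c3cccc(NC(=O)Nc4ccc(Cl)c(Cl)c4)c3)cc2-c2ccncc2)ccc1Cl`, a limit of > 50000 nM

In a functional assay on SF-295 cells (Homo sapiens) for inhibition, read by sulforhodamine B assay, with a stated time of 48 h (on this read-out higher numbers stand for lower toxicity in this test and lower numbers for higher toxicity in this test), compound 2 gives the lowest of the two numbers; compound 1 sits within the scatter of it. Compound 3 reaches only a limit of the assay. Among the compounds with values here, the one measured step, an at least 15-fold higher number from compound 2 to compound 3 (1.19 log units; beyond the scatter), concerns a different change on the same ring and does not directly bear on the present one (the limit of > 50000 nM in this assay, at which 1 of the 3 values shown sits). Compound 4 `COc1cc(-c2nn(-c3cccc(NC(=O)Nc4cc(C(F)(F)F)cc(C(F)(F)F)c4)c3)cc2-c2ccncc2)ccc1Cl` differs from compound 2 by trifluoromethyl in place of hydrogen on an aromatic carbon. Compound 4 carries the same urea aryl group as compound 1, which gives 4390 nM, so little change is expected: a 1.3-fold higher number from compound 2 to compound 4 (0.10 log units; within the scatter). Compound 4 is therefore estimated at 4000 nM, between 1500 nM and 12000 nM.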

Compound 4, concentration lethal to 50% of the cells: 3310 nM
Estimate against measurement, compound 4: 1.2-fold (0.08 log units) above; low and high end bracket the measured number.
By their numbers in this assay, from the lowest: compounds 2, 4 and 1 (each within the scatter of the next). At a limit, above all of these: compound 3.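

Read in this assay the second trifluoromethyl makes no difference that can be told apart: a 1.0-fold higher number from compound 2 to compound 4 (0.01 log units; within the scatter) is all it gives at this place on the urea aryl ring. With this second group present, methyl in place of hydrogen on the oxygen on the aromatic ring also stays within the scatter, with a 1.3-fold lower number from compound 1 to compound 4 (0.12 log units; within the scatter) as its step. Nothing measured here gives a reason for either result. Going by these compounds, whether an amine or a carboxylic acid on this same aromatic carbon would leave the number equally unmoved remains open.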